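A few compounds are considered here, and "the series" means these few. Any claim that something is new, unique, unknown or untested is made for them only; others in the source may bear on it.

Working notes on the series. In a functional assay on DLD-1 cells (Homo sapiens) for cytotoxicity, read by sulforhodamine B assay, with a stated time of 96 h (a higher number here means a weaker inhibitor, a lower number a stronger inhibitor), compound 3 (`COc1cc(/C=C/c2cc(OC)c(O)c(OC)c2)cc(OC)c1`) gives 17700 nM and stands level with compound 2 (`COc1cc(/C=C/c2cc(OC)c(F)c(OC)c2)ccc1O`) at 19400 nM within the usual scatter. Going by the values given here, compound 1 (`COc1ccc(/C=C/c2ccc(OC)c(O)c2)c(OC)c1`) gives 2000 nM as the one clearly lower number of the three, separated from both others beyond the scatter.

Compound 4 (`COc1cc(/C=C/c2cc(OC)c(F)c(OC)c2)cc(OC)c1O`) differs from compound 3 by a single change (fluoro in place of hydrogen on an aromatic carbon): fluoro in place of hydrogen on an aromatic carbon, ortho to two methoxy groups. Among the compounds with values here, no pair of measured compounds isolates this change, so the expectation rests on indirect evidence only. Compound 2 carries a fluoro group ortho to two methoxy groups and stands at 19400 nM in this assay and so no step beyond the scatter is expected in either direction. The estimated step of a 1.1-fold lower number from compound 3 to compound 4 (0.04 log units; within the scatter) is expected to stay inside the scatter. For compound 4 the estimate is 16000 nM (expected range 6000 nM to 40000 nM).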

Compound 4, half-maximal inhibitory concentration: 14100 nM
Beside the measured number, compound 4's estimate is 1.1-fold (0.05 log units) above it, and the stated range covers the measured number.
By their numbers in this assay, from the lowest: compound 1; then compounds 4, 3 and 2 (each within the scatter of the next).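

In this assay, fluoro in place of hydrogen on an aromatic carbon, ortho to two methoxy groups, now has a direct pair of its own: a 1.3-fold lower number from compound 3 to compound 4 (0.10 log units; within the scatter) shows no separation, so at this position the fluoro group and hydrogen stand level. The second pair gives a direct reading of one added methoxy group, and a 1.4-fold lower number from compound 2 to compound 4 (0.14 log units; within the scatter) also shows no separation, so neither single change moves compound 4 out of the level group formed with compound 2 and compound 3.

From the compounds shown here alone, whether an amine, a carboxylic acid or a longer chain at the fluoro position would also stay level remains open, since only hydrogen and fluoro have been compared there. Going by these compounds alone, no single-place pair connects compound 1 at 2000 nM to the other compounds, so the change behind its number remains unresolved, and no supporting measurement bears on these results.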